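The source may report more compounds than this note shows. Statements on the series, on what has been measured and on what is new or still open speak of the compounds shown alone.

Measured so far:
compound 1, `Cc1ccn2nc(C)c(C(=O)NCc3ccc(N4CCC(c5ccc(OC(F)(F)F)cc5)CC4)cc3)c2n1`: "not determined" (no result reported)
compound 2, `Cc1nn2c(C)csc2c1C(=O)NCc1ccc(N2CCC(c3ccc(OC(F)(F)F)cc3)CC2)cc1`: > 100000 nM

Two compounds share the same amide-linked piperidine tail and differ only in their fused core. For compound 1, `Cc1ccn2nc(C)c(C(=O)NCc3ccc(N4CCC(c5ccc(OC(F)(F)F)cc5)CC4)cc3)c2n1`, the result in a toxicity assay on Vero cells (Chlorocebus sabaeus) for cytotoxicity, read by CCK-8 assay, with a stated time of 72 h (a higher number here means a weaker inhibitor, a lower number a stronger inhibitor), is "not determined" (no result reported), so it gives no number to work from. Among the measured compounds shown here, compound 2, `Cc1nn2c(C)csc2c1C(=O)NCc1ccc(N2CCC(c3ccc(OC(F)(F)F)cc3)CC2)cc1`, is the only compound with an entry: in this assay compound 2 gives > 100000 nM, which is a limit of the assay and not a measured number. This is where compound 2 stands, at the limit of > 100000 nM in this assay, at which 1 of the 2 values shown sits; it is the top of what the assay reports, and no single number lies anywhere on the scale.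

Compound 3, `Cc1nn2ccsc2c1C(=O)NCc1ccc(N2CCC(c3ccc(OC(F)(F)F)cc3)CC2)cc1`, has not yet been measured. It differs from compound 2 by hydrogen in place of methyl on an aromatic carbon. For the measured compounds named here, since no step between measured compounds exists, the size of the step can only be expected: a change of one carbon on the core is expected to move this assay by no more than the scatter, in no particular direction. Compound 3 is therefore expected to sit at 100000 nM, in the range 50000 nM to 200000 nM, and the expected step is a number no higher from compound 2 to compound 3 (the limit leaves the size open).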

Compound 3, half-maximal inhibitory concentration: > 100000 nM
Compound 3 gave a limit, no number; the forecaster's own chance of this, stated with the estimate: 85%; the middle value sits exactly at the limit.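

In this assay compound 2 and compound 3 both give only a limit and not a number, so the step between them, hydrogen in place of methyl on an aromatic carbon, cannot be read. The compounds shown leave open at what concentration either compound would affect these cells, and whether that methyl changes it.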